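Cyclopentyl amide in place of the fluorophenyl amide

The source may report more compounds than this note shows. Statements on the series, on what has been measured and on what is new or still open speak of the compounds shown alone.

Three members of the series have numbers in a physicochemical assay for lipophilicity, at pH 7.4; a lower number here means a more polar compound, a higher number a more lipophilic compound. Compound 1 `Cc1cc(C(=O)O)nn1C(C)c1cc(Cl)ccc1OCc1ccccc1` gives 1 in this assay. Compound 2 `Cc1cc(C(=O)Nc2ccc(F)cc2)nn1Cc1cc(Cl)ccc1OCc1ccccc1` gives 3 in this assay, and compound 3 `Cc1cc(C(N)=O)nn1Cc1cc(Cl)ccc1OCC(C)C` gives 3.1 in this assay. Among these three numbers compound 2 stands second highest: compound 3 lies within the scatter of it, so no order between compound 2 and compound 3 can be read, while compound 1 lies far below compound 2, beyond the scatter. Within the data shown here, no pair of measured compounds differs in only one place, so no measured single step is available to lean on.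

Compound 4 `Cc1cc(NC(=O)C2CCCC2)nn1Cc1cc(Cl)ccc1OCc1ccccc1` is the next to be measured in this assay. Against compound 2 the change is this: (cyclopentylcarbonyl)amino in place of (4-fluorophenyl)carbamoyl on an aromatic carbon. The group that leaves carries a six-membered aromatic ring and a fluorine; the group that enters carries a five-membered non-aromatic ring and two heavy atoms fewer, with the same count of donors and acceptors. With nothing measured for this kind of change in the series, a modest step downward, of a size near the edge of the scatter, is expected from compound 2 to compound 4 in this assay, a number 0.40 log units lower from compound 2 to compound 4 (beyond the scatter). Compound 4 is therefore estimated at 2.6 in this assay, with a range from 2.1 to 3.1.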

Compound 4, distribution coefficient: 3.5
Beside the measured number, compound 4's estimate is 0.90 log units below it; measured number outside the range, above it.
By their numbers in this assay, from the lowest: compound 1; then compounds 2 and 3 (each within the scatter of the next); then compound 4.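

In this assay, among these compounds, (cyclopentylcarbonyl)amino in place of (4-fluorophenyl)carbamoyl on this aromatic carbon gives a number 0.50 log units higher from compound 2 to compound 4 (beyond the scatter), the first step read across a change in one place. In this one pair, the number rises even though the entering group has fewer heavy atoms, no fluorine and a five-membered non-aromatic ring instead of a six-membered aromatic ring, so at this position neither the aromatic ring nor the fluorine is needed to keep the number up. Nothing shown bears on why the step runs in this direction.

The step combines three differences, namely the ring, the fluorine and the direction of the amide, and the compounds shown cannot separate them from one another. A cyclopentylcarbamoyl or an unsubstituted phenylcarbamoyl group on this carbon would divide the step into its parts, while a simple amine there would show how much of the number depends on having an amide at this position at all.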